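Nitro for Trifluoromethyl on the Sulfonyl Ring

This account rests on a few compounds, and the source may have more. Where it says the series, first, only, none or still open, it means among the compounds named here.

Compound 1, `O=S(=O)(NCCCCCCNCc1ccc(Br)cc1)c1ccc(C(F)(F)F)cc1`: in a functional assay on MIA PaCa-2 cells (Homo sapiens) for inhibition, read by MTT assay, with a stated time of 72 h (a higher number here means a weaker inhibitor of growth, a lower number a stronger inhibitor of growth), compound 1 gives 3830 nM.
Compound 2, `CN(CCCNS(=O)(=O)c1cc(C(F)(F)F)cc(C(F)(F)F)c1)Cc1ccccc1`: in this assay compound 2 gives 33000 nM.
Compound 3, `COc1ccccc1CNCCCNS(=O)(=O)c1cc(C(F)(F)F)cc(C(F)(F)F)c1`: in this assay compound 3 gives 3100 nM.

Among these three, compound 1 carries the second highest number. Compound 3 sits closest to it, within the usual scatter, while compound 2 lies well above it, beyond the scatter. Going by the values given here, the one step that can be traced between two neighbours, an 11-fold lower number from compound 2 to compound 3 (1.03 log units; beyond the scatter), concerns the amine end of the chain and leaves the sulfonyl ring untouched.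

Compound 4, `O=[N+]([O-])c1ccc(S(=O)(=O)NCCCCCCNCc2ccc(Br)cc2)cc1`, differs from compound 1 at that other end: nitro in place of trifluoromethyl on an aromatic carbon. Among the compounds with values here, no measured pair alters the substituent on the sulfonyl ring, so none of the measured steps bears on this change, and the expectation rests on compound 1 alone with 3830 nM in this assay. The expected step is therefore a 1.0-fold higher number from compound 1 to compound 4 (0.02 log units; within the scatter), nothing beyond the scatter in either direction. For compound 4 the estimate is 4000 nM, with a range from 1500 nM to 11000 nM.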

Compound 4, concentration for 50% growth inhibition: 9800 nM
Compound 4: the middle estimate sits 2.5-fold (0.39 log units) below what was measured; the measured number falls inside the stated range.
By their numbers in this assay, from the lowest: compounds 3 and 1 (each within the scatter of the next); then compound 4; then compound 2.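

In this assay, going by these compounds alone, nitro in place of trifluoromethyl, on an aromatic carbon para to a large group, gives a 2.6-fold higher number from compound 1 to compound 4 (0.41 log units; beyond the scatter) and is the first measured change on the sulfonyl ring. This position is therefore not indifferent to its substituent: with the rest of compound 1 unchanged, nitro gives the weaker inhibitor of growth, though this step is smaller than an 11-fold lower number from compound 2 to compound 3 (1.03 log units; beyond the scatter) at the amine end of the chain. No evidence is available on what lies behind the difference between the two groups.

The compounds shown leave open how other groups at this position, such as a nitrile, a carboxylic acid or an amine, would compare with trifluoromethyl and nitro. They also leave open whether the same exchange would give a similar step on a shorter chain or with a different group at the amine end.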